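A few compounds are considered here, and "the series" means these few. Any claim that something is new, unique, unknown or untested is made for them only; others in the source may bear on it.

Compound 2, `COc1c(Br)cc(Br)cc1C(=O)Nc1ccc(Sc2nc3ccccc3s2)c(Cl)c1`, was tested in an assay for inhibition of HSP60/HSP10 (Homo sapiens), with a stated time of 60 min; on this read-out higher numbers stand for weaker inhibition and lower numbers for stronger inhibition. In this assay compound 2 gives only a limit, > 100000 nM, and no number. Compound 1, `COc1c(Br)cc(Br)cc1C(=O)Nc1ccccc1`, shares the same core with it; in this assay compound 1 likewise reaches only a limit, > 100000 nM. Both values shown therefore stand at the limit of > 100000 nM in this assay, at which 2 of the 2 values shown sit, so neither compound has a measured strength of inhibition, and the two cannot be ranked against each other.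

Compound 3, `COc1c(Br)cc(Br)cc1C(=O)Nc1cccc(Cl)c1`, is not yet measured. Compared with compound 2, the change is hydrogen in place of (1,3-benzothiazol-2-yl)sulfanyl on an aromatic carbon. For the measured compounds named here, no measured step between two compounds differing in one place exists here, and both compounds shown sit at the limit, so there is no sign of a gain or a loss to build on; the expected step that the limit leaves unreadable from compound 2 to compound 3 is none beyond the scatter. Compound 3 is estimated at 150000 nM, within a range from 50000 nM to 500000 nM, most likely again only a limit.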

Compound 3, half-maximal inhibitory concentration: > 100000 nM
Compound 3 was reported as a limit (the forecaster's own chance of this, stated with the estimate: 85%); the middle value does not contradict the limit.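

Compound 3 also reaches only a limit in this assay, so the steps linking it to compound 1 and compound 2 cannot be read: the limit of > 100000 nM in this assay, at which 3 of the 3 values shown sit. None of the three compounds has a measured strength of inhibition, which leaves open whether the chloro or (1,3-benzothiazol-2-yl)sulfanyl group changes it at all.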